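Moving the chlorine on the aryl group beside the ring nitrogen

The source may report more compounds than this note shows. Statements on the series, on what has been measured and on what is new or still open speak of the compounds shown alone.

Of the compounds shown here, two have been measured in a functional assay on DU-145 cells (Homo sapiens) for cytotoxicity, read by CCK-8 assay and cell counting, with a stated time of 2 days; a lower number here means a stronger inhibitor, a higher number a weaker inhibitor. Compound 1 `Oc1ccc(-c2cc(-c3cccc(Cl)c3)nc(-c3ccccn3)c2)cc1` gives 35200 nM. Compound 2 `Oc1ccc(-c2cc(-c3ccccc3)nc(-c3ccc(Cl)cc3)c2)cc1` gives 7270 nM, the lowest of the two numbers, and its distance from compound 1 lies beyond the scatter. For the measured compounds named here, no single step between measured compounds is available, since the two differ in more than one place.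

Compound 3 `Oc1ccc(-c2cc(-c3ccccc3)nc(-c3cccc(Cl)c3)c2)cc1` has not yet been measured. It is related to compound 2 by one change: 3-chlorophenyl in place of 4-chlorophenyl on an aromatic carbon. This swap of one chlorophenyl for the other on the shared core exchanges no atoms, only their arrangement.

With no comparable step among the measured compounds, the account can only reason from compound 2. Such an exchange is expected to give at most a modest step, and the direction cannot be read from the data with confidence; a slight move toward a higher number is estimated, of a size that may well stay within the scatter. Compound 3 is therefore expected to give about 9000 nM in this assay, within a range from 3000 nM to 27000 nM, which corresponds to an expected step of a 1.2-fold higher number from compound 2 to compound 3 (0.09 log units; within the scatter).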

Compound 3, half-maximal inhibitory concentration: 5360 nM
For compound 3 the middle estimate is 1.7-fold (0.23 log units) above the measured one, within the range that was stated.
By their numbers in this assay, from the lowest: compounds 3 and 2 (each within the scatter of the next); then compound 1.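

In this assay, moving the chlorine from 4-chlorophenyl to 3-chlorophenyl gives a 1.4-fold lower number from compound 2 to compound 3 (0.13 log units; within the scatter), so this first comparison of the two arrangements separates them by no more than repeated measurements would, and the chlorine's placement on this aryl group shows no readable effect in this pair. Compound 3 also links compound 1 to the series through a single change: phenyl in place of pyridin-2-yl gives a 6.6-fold lower number from compound 1 to compound 3 (0.82 log units; beyond the scatter), so in this pair the exchange of that aromatic group matters more than the chlorine move does. Nothing is available that would explain either step.

The compounds shown leave open whether a 2-chlorophenyl, or an aryl group carrying an amine or a carboxylic acid in place of the chlorine, would stay at the level of compound 2 and compound 3. They also leave open whether the step from pyridin-2-yl to phenyl would be of similar size with 4-chlorophenyl on the shared core, since that step rests on one pair alone.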